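Compound 4: (pyrrolidin-1-yl)methyl for cyclopropylcarbamoyl on compound 1

This account rests on a few compounds, and the source may have more. Where it says the series, first, only, none or still open, it means among the compounds named here.

The series is followed in an assay for inhibition of RAC-alpha serine/threonine-protein kinase (Homo sapiens), read by HTRF, with a stated time of 1 h; a lower number here means a stronger inhibitor, a higher number a weaker inhibitor. Compound 1 `Cn1ncc(Cl)c1-c1cc(C(=O)N[C@@H]2CN[C@H](CC(=O)NC3CC3)C[C@H]2c2ccc(Cl)c(Cl)c2)oc1Cl` gives 3.95 nM, the higher of the two numbers in hand, though compound 3 `CC(=O)OCC[C@@H]1C[C@@H](c2ccc(F)c(F)c2)[C@H](NC(=O)c2cc(-c3c(Cl)cnn3C)c(Cl)o2)CN1` at 3.4 nM sits within the scatter of it, so the two are treated as equal. For compound 2 `O=C(N[C@@H]1CNCC[C@H]1c1ccc(Cl)cc1)c1ccc(-c2ncnc3c2CCC3O)s1` only a limit is recorded, > 1000 nM, which is the limit of > 1000 nM in this assay, at which 1 of the 3 values shown sits.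

Compound 4 `Cn1ncc(Cl)c1-c1cc(C(=O)N[C@@H]2CN[C@H](CCN3CCCC3)C[C@H]2c2ccc(Cl)c(Cl)c2)oc1Cl` is not yet measured. It differs from compound 1 in one place, ((pyrrolidin-1-yl)methyl in place of cyclopropylcarbamoyl on a saturated chain carbon bound to a saturated ring carbon), the same shared core and the same aryl substituents being kept. Within the data shown here, no pair of measured compounds differs by this kind of change, so the only anchor is the value of compound 1.

The expected step is a 1.3-fold higher number from compound 1 to compound 4 (0.10 log units; within the scatter), no further than the usual scatter and, if anything, slightly toward a higher number. On that basis compound 4 is estimated at 5 nM in this assay, with a range from 1.5 nM to 20 nM.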

Compound 4, half-maximal inhibitory concentration: 6.41 nM
Compound 4: the middle estimate sits 1.3-fold (0.11 log units) below what was measured; the range from low to high includes it.
By their numbers in this assay, from the lowest: compounds 3, 1 and 4 (each within the scatter of the next). At a limit, above all of these: compound 2.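

In this assay the series gives a 1.6-fold higher number from compound 1 to compound 4 (0.21 log units; within the scatter) when (pyrrolidin-1-yl)methyl replaces cyclopropylcarbamoyl on a saturated chain carbon bound to a saturated ring carbon. This exchange removes the carbonyl and the amide hydrogen and replaces the three-membered carbon ring with a five-membered ring holding one hetero atom, so neither the carbonyl nor the amide hydrogen is required at this position for a value within the scatter of compound 1. No measurement shown explains this step or ties it to a property of either group.

Still open, as far as these compounds go, is whether the pyrrolidine ring itself matters, which a dimethylamino group on the same chain would test. A carboxylic acid at this position, or a longer chain carrying the pyrrolidine, would show how far the position tolerates other groups.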